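Thiophen-3-yl in place of methoxyphenyl on the carbonyl

A few compounds are considered here, and "the series" means these few. Any claim that something is new, unique, unknown or untested is made for them only; others in the source may bear on it.

compound 1, `COc1ccc(C(=O)/C=C/c2nc3ccccc3cc2-c2ccc(OC)cc2)cc1`: > 10000 nM
compound 2, `COc1ccc(-c2cc3ccccc3nc2/C=C/C(=O)c2c(OC)cccc2OC)cc1`: 4470 nM
compound 3, `COc1ccc(-c2cc3ccccc3nc2/C=C/C(=O)c2ccc([N+](=O)[O-])cc2)cc1`: 6100 nM

The three measured compounds share one core and differ only in the aryl group on the carbonyl carbon. In a functional assay on H184B5F5/M10 cells (Homo sapiens) for antiproliferative activity, read by XTT assay, with a stated time of 72 h (on this read-out higher numbers stand for weaker inhibition and lower numbers for stronger inhibition), compound 1 reaches only a limit of the assay, > 10000 nM. Compound 1 therefore stands at the weak end of what has been measured, sitting at the limit of > 10000 nM in this assay, at which 1 of the 3 values shown sits. Compound 2 gives 4470 nM and compound 3 gives 6100 nM in the same assay.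

Compound 4, `COc1ccc(-c2cc3ccccc3nc2/C=C/C(=O)c2ccsc2)cc1`, is changed at the same place as the other two: thiophen-3-yl in place of 4-methoxyphenyl on a carbonyl carbon. Going by the values given here, two measured steps bear on this change, both starting from compound 1 and both swapping the group on the carbonyl carbon: an at least 2.2-fold lower number from compound 1 to compound 2 (0.34 log units; beyond the scatter) and an at least 1.6-fold lower number from compound 1 to compound 3 (0.21 log units; that floor lies within the scatter). Both move away from the limit, one of them beyond the scatter. The pair of compound 2 and compound 3 shows a 1.4-fold higher number from compound 2 to compound 3 (0.14 log units; within the scatter), so the two replacements land in the same region. A lower number is therefore expected for compound 4, with its size uncertain since the starting point is only a limit. The expected step is an at least 1.6-fold lower number from compound 1 to compound 4 (0.22 log units; that floor lies within the scatter). Compound 4 is estimated at 6000 nM, with a range from 2500 nM to 15000 nM.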

Compound 4, half-maximal inhibitory concentration: 6390 nM
Compound 4: the middle estimate sits 1.1-fold (0.03 log units) below what was measured; the range from low to high includes it.
By their numbers in this assay, from the lowest: compounds 2, 3 and 4 (each within the scatter of the next). At a limit, above all of these: compound 1.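

Thiophen-3-yl on the carbonyl carbon, a five-membered aromatic ring with one hetero atom, falls in the same region as the two six-membered replacements, a 1.0-fold higher number from compound 3 to compound 4 (0.02 log units; within the scatter) and a 1.4-fold higher number from compound 2 to compound 4 (0.16 log units; within the scatter), so in this assay compounds 2, 3 and 4 cannot be told apart, and only compound 1 goes against this. Among the compounds shown, this level therefore does not depend on a six-membered ring of carbon on this carbonyl carbon, which the earlier compounds could not show. The step out of the 4-methoxyphenyl group is only a floor, an at least 1.5-fold lower number from compound 1 to compound 4 (0.19 log units; that floor lies within the scatter); the value of compound 1 is a limit of the assay, which leaves the true size of that step unknown: the limit of > 10000 nM in this assay, at which 1 of the 4 values shown sits.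

From the compounds shown here alone, whether any group on this carbonyl carbon can move the number beyond the scatter of compounds 2, 3 and 4 stays open, for example a pyridine ring, an aminophenyl group or a carboxylic acid on the phenyl ring. Going by these compounds, the 4-methoxyphenyl group on the shared core is the same in all four compounds, so what it contributes also stays open.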